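Compound 4: hydrogen in place of ethyl on the ring amine

The source may report more compounds than this note shows. Statements on the series, on what has been measured and on what is new or still open speak of the compounds shown alone.

In an in vivo ADME assay on the whole organism (plasma, strain Sprague-Dawley) for pharmacokinetics, with Rattus norvegicus as the target, read by LC-MS (on this read-out lower numbers stand for slow clearance and higher numbers for fast clearance), compound 2 (`CCN1CCC(Oc2ccnc(C(=O)Nc3ccc(NC(=O)Nc4cc(C(C)(C)C)on4)cc3)c2)CC1`) has no single number, its entry reading "not determined" (no result reported) and leaving nothing to step from. Compound 4 (`CC(C)(C)c1cc(NC(=O)Nc2ccc(NC(=O)c3cc(OC4CCNCC4)ccn3)cc2)no1`) differs from it by one change (hydrogen in place of ethyl on an amine nitrogen in a ring): hydrogen in place of ethyl on an amine nitrogen in a ring. Among the compounds with values here, no measured step makes this exact change. In this assay compound 1 (`CC(C)(C)c1cc(NC(=O)Nc2ccc(NC(=O)c3ccc(OC4CCN(C(C)(C)C)CC4)cn3)cc2)no1`) gives 15 mL/min/kg and compound 3 (`CC1(C)CC(Oc2ccc(C(=O)Nc3ccc(NC(=O)Nc4cc(C(C)(C)C)on4)cc3)nc2)CC(C)(C)N1`) gives 11 mL/min/kg as its clearance. Within the data shown here, the one step that bears on the change (a 1.4-fold lower number from compound 1 to compound 3 (0.13 log units; within the scatter)) puts 2,2,6,6-tetramethylpiperidin-4-yl in place of 1-(tert-butyl)piperidin-4-yl. No shift beyond the scatter is therefore expected from these two values. For compound 4 the expected clearance is 15 mL/min/kg (estimated range 7 mL/min/kg to 32 mL/min/kg).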

Compound 4, clearance: 35.8 mL/min/kg
Compound 4: middle estimate off by 2.4-fold (0.38 log units), on the low side, outside the stated range (above it).
By their numbers in this assay, from the lowest: compounds 3 and 1 (each within the scatter of the next); then compound 4.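

Within the data shown here, no step to compound 4 can be read in this assay, as compound 2 has no single number there. The compounds shown leave open what hydrogen in place of ethyl does to clearance. Nothing here offers an explanation for the value of compound 4.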